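The source may report more compounds than this note shows. Statements on the series, on what has been measured and on what is new or still open speak of the compounds shown alone.

Within the data shown here, compound 1 `CC(=O)Nc1ccc(S(=O)(=O)Oc2ccccc2I)cc1` is the first of three compounds examined in a functional assay on HT-29 cells (Homo sapiens) for antiproliferative activity, read by sulforhodamine B assay, with a stated time of 48 h; a lower number here means a stronger inhibitor, a higher number a weaker inhibitor. In this assay compound 1 gives 23000 nM. Compound 2 `CCCC(=O)Nc1ccc(S(=O)(=O)Oc2ccccc2I)cc1` carries one change relative to compound 1, (ethyl in place of hydrogen on a saturated chain carbon bound to a carbonyl carbon), and in this assay compound 2 gives 11000 nM. That change produced a 2.1-fold lower number from compound 1 to compound 2 (0.32 log units; beyond the scatter).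

Compound 3 `CCCNC(=O)Nc1ccc(S(=O)(=O)Oc2ccccc2C(C)C)cc1` rests on a different core; the difference between the two cores is not broken down here. In this assay compound 3 gives 6300 nM. Set beside compound 2, the number for compound 3 lies within the usual scatter, so the two values cannot be told apart; set beside compound 1, the number for compound 3 is clearly lower, but nothing beyond the two values themselves is shown for that pair.

Compound 4 `CCCCCNC(=O)Nc1ccc(S(=O)(=O)Oc2ccccc2C(C)C)cc1` has not yet been measured. It differs from compound 3 by ethyl in place of hydrogen on a saturated chain carbon, three bonds along the chain from an amide-type nitrogen. Among the measured compounds shown here, this is the same kind of change as the one from compound 1 to compound 2, but not the same: there the entering ethyl sat on a saturated chain carbon bound to a carbonyl carbon, whereas here it sits on a saturated chain carbon, three bonds along the chain from an amide-type nitrogen. Because the earlier change gave a 2.1-fold lower number from compound 1 to compound 2 (0.32 log units; beyond the scatter), a step of comparable direction, though weaker, is expected here, namely a 1.6-fold lower number from compound 3 to compound 4 (0.20 log units; within the scatter). On that basis compound 4 is estimated to give 4000 nM in this assay, with a plausible range from 1500 nM to 10000 nM.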

Compound 4, half-maximal inhibitory concentration: 4900 nM
Beside the measured number, compound 4's estimate is 1.2-fold (0.09 log units) below it; the measured number falls inside the stated range.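

Carried onto the second core, the ethyl-for-hydrogen change gave a 1.3-fold lower number from compound 3 to compound 4 (0.11 log units; within the scatter) in this assay, so this step alone cannot be told apart from no change at all. Set beside the earlier step, it points the same way, and the gap between the two steps is too small to count as a real difference between the cores: the same change on two cores in this assay, a 2.1-fold lower number (0.32 log units; beyond the scatter) from compound 1 to compound 2 and a 1.3-fold lower number (0.11 log units; within the scatter) from compound 3 to compound 4, 1.6-fold (0.21 log units) apart, within the scatter of two such steps. Among these compounds, this shows that nothing here separates the behaviour of the change on the two cores, but it does not show that the change transfers fully, as each core offers only one pair and the ethyl enters at a different place on each, on a saturated chain carbon bound to a carbonyl carbon in one and on a saturated chain carbon, three bonds along the chain from an amide-type nitrogen, in the other.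

The compounds shown leave open whether a chain longer than pentyl, or a chain ending in an amine or a carboxylic acid, would shift the number on the core of compound 3 beyond the scatter. They also leave open whether a cyclohexyl group in place of the chain would read alike on the core of compound 1 and on the core of compound 3.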